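This account rests on a few compounds, and the source may have more. Where it says the series, first, only, none or still open, it means among the compounds named here.

Working notes on the series.

Among the compounds with values here, compound 1 `CN1CCC(C(=O)N2Cc3c(NC(=O)C4CC4)n[nH]c3C2(C)C)CC1` is the weakest of the three compounds measured so far: in a functional assay on A2780 cells (Homo sapiens) for antiproliferative activity, read by fluorescence, with a stated time of 72 h (on this read-out higher numbers stand for weaker inhibition and lower numbers for stronger inhibition), compound 1 gives 1420 nM, the highest number of the set. Compound 3 `CN(C)CC(=O)Nc1n[nH]c2c1CN(C(=O)C(C)(C)C)C2(C)C` gives 580 nM in this assay, a number lower than that of compound 1 by more than the scatter of repeated measurements. Compound 2 `CC1(C)c2[nH]nc(NC(=O)c3ccc(F)cc3)c2CN1C(=O)C1CCN(C2CC2)CC1` gives 380 nM in this assay, the lowest number of the three and again separated from compound 1 by more than the scatter. Within the data shown here, no two compounds of this set differ in one place only, so none of these gaps can be assigned to a single structural change.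

Compound 4 `CN1CCC(C(=O)N2Cc3c(NC(=O)c4cccc(F)c4)n[nH]c3C2(C)C)CC1` has not yet been measured. It differs from compound 1 in one place: 3-fluorophenyl in place of cyclopropyl on a carbonyl carbon. Compound 2 carries an aromatic fluorophenyl group on the amide carbonyl and gives 380 nM, although it differs from compound 1 elsewhere as well. On that basis the expected step for compound 4 in this assay is a 2.8-fold lower number from compound 1 to compound 4 (0.45 log units; beyond the scatter), a moderate move to a lower number, beyond the scatter but not large. For compound 4 the estimate in this assay is 500 nM, with a range from 200 nM to 1400 nM.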

Compound 4, half-maximal inhibitory concentration: 200 nM
Estimate against measurement, compound 4: 2.5-fold (0.40 log units) above; the range from low to high includes it.
By their numbers in this assay, from the lowest: compounds 4, 2 and 3 (each within the scatter of the next, the first and the last beyond it); then compound 1.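

Within the data shown here, the exchange of cyclopropyl for 3-fluorophenyl on a carbonyl carbon gives the first step that belongs to a single structural change: in this assay it is a 7.1-fold lower number from compound 1 to compound 4 (0.85 log units; beyond the scatter) with the rest of the core of compound 1 held fixed. Among these compounds, the gaps among the earlier compounds could not be assigned to any one place, whereas this one shows that the group on this carbonyl alone can move the number by more than the scatter, and that a six-membered aromatic ring of 7 heavy atoms is tolerated here in place of a three-membered ring of 3 heavy atoms. The data give no measured reason for this step.

The step cannot separate the contribution of the aromatic ring from that of the fluorine, so a plain phenyl group or a pyridine ring would be needed to tell them apart, and a cyclohexyl group would test ring size without aromaticity. Steps involving compound 2 or compound 3 cannot be read, as each differs from the others in more than one place.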